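Triazole nitrogen substituent: benzyl to pyridin-3-yl

This account rests on a few compounds, and the source may have more. Where it says the series, first, only, none or still open, it means among the compounds named here.

Compound 2 `CC(C)=CCC1=C(OCc2cn(Cc3ccccc3)nn2)C(=O)c2ccccc2C1=O` holds the higher of the two numbers in an ADME assay on HepG2 cells (Homo sapiens) for cytotoxicity, read by MTT assay, with a stated time of 24 h (on this read-out higher numbers stand for lower toxicity in this test and lower numbers for higher toxicity in this test), where compound 2 gives 414000 nM. In this assay compound 1 `CC(C)=CCC1=C(OCc2cn(C3CCN(C(=O)OC(C)(C)C)CC3)nn2)C(=O)c2ccccc2C1=O` gives 136000 nM, a lower number beyond the usual scatter. Compound 3 `CC(C)=CCC1=C(OCc2cn(-c3cccnc3)nn2)C(=O)c2ccccc2C1=O` carries the change (pyridin-3-yl in place of benzyl on an aromatic nitrogen). Going by the values given here, no measured pair tracks an aryl group in place of benzyl at this position, so no step beyond the scatter is assumed in either direction. For compound 3 the value in this assay is expected near 300000 nM, within 100000 nM to 900000 nM. The step from a 1.4-fold lower number from compound 2 to compound 3 (0.14 log units; within the scatter) is thus an estimate only.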

Compound 3, half-maximal cytotoxic concentration: 1030000 nM
Estimate against measurement, compound 3: 3.4-fold (0.54 log units) below; measured number outside the range, above it.
By their numbers in this assay, from the lowest: compound 1; then compound 2; then compound 3.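

In this assay the group on this aromatic nitrogen clearly matters: pyridin-3-yl in place of benzyl gives a 2.5-fold higher number from compound 2 to compound 3 (0.40 log units; beyond the scatter) and so moves the read-out towards lower toxicity in this test. The change both removes the benzyl carbon link and brings a ring nitrogen, and this single pair does not separate the two. Nothing measured here accounts for the step. Still open, on these data alone, is whether phenyl, pyridin-2-yl or pyridin-4-yl would move the number the same way, and what an amine or a carboxylic acid on the ring would do.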